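Shortening the Ester Chain from Compound 3 to Compound 4

This account rests on a few compounds, and the source may have more. Where it says the series, first, only, none or still open, it means among the compounds named here.

Three esters of the shared core have been measured in a functional assay on HeLa cells (Homo sapiens) for cytotoxicity, read by cell counting, with a stated time of 48 h; a lower number here means that less compound is needed, a higher number that more compound is needed for the effect. Compound 1 `CCCCCCC/C=C\C(=O)O[C@H]1[C@H](O)[C@H](n2ccc(N)nc2=O)O[C@@H]1CO` gives 0.06 ug/mL, compound 2 `CCCCCCCCCCCCCCCC(=O)O[C@H]1[C@H](O)[C@H](n2ccc(N)nc2=O)O[C@@H]1CO` gives 0.24 ug/mL, and compound 3 `CCCCCCCCCCC(=O)O[C@H]1[C@H](O)[C@H](n2ccc(N)nc2=O)O[C@@H]1CO` gives 0.04 ug/mL. Within the data shown here, compound 3 thus shows the lowest of the three numbers, though compound 1 lies within the scatter of it; only compound 2 stands clearly apart, and the single measured step, a 6.0-fold lower number from compound 2 to compound 3 (0.78 log units; beyond the scatter), is the one that bears on a shortened chain. Compound 4 `CCCCCCCCC(=O)O[C@H]1[C@H](O)[C@H](n2ccc(N)nc2=O)O[C@@H]1CO` continues in that direction: hydrogen in place of ethyl on a saturated chain carbon, eight bonds along the chain from a carbonyl carbon. Because a 6.0-fold lower number from compound 2 to compound 3 (0.78 log units; beyond the scatter) lowered the number while compound 1 at 0.06 ug/mL sits close to compound 3, the author expects in this assay no step beyond the scatter, a 1.5-fold higher number from compound 3 to compound 4 (0.18 log units; within the scatter). Compound 4 is accordingly estimated at 0.06 ug/mL, within 0.025 ug/mL to 0.15 ug/mL.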

Compound 4, concentration for half-maximal effect: 0.05 ug/mL
For compound 4 the middle estimate is 1.2-fold (0.08 log units) above the measured one, within the range that was stated.
By their numbers in this assay, from the lowest: compounds 3, 4 and 1 (each within the scatter of the next); then compound 2.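

In this assay the loss of ethyl at this place, eight bonds along the chain from a carbonyl carbon, changes little, with a 1.3-fold higher number from compound 3 to compound 4 (0.10 log units; within the scatter) and, against the unsaturated ester, a 1.2-fold lower number from compound 1 to compound 4 (0.08 log units; within the scatter), so compounds 1, 3 and 4 cannot be ordered. The long saturated ester alone stands apart, with a 4.8-fold lower number from compound 2 to compound 4 (0.68 log units; beyond the scatter), so the shortening seen in compound 3 holds for a further cut of the chain. No measurement at hand gives a cause for this. On these data alone, it stays open where along the chain lengths from compound 3 to compound 2 the number begins to rise. Also open, as far as these compounds go, is whether a chain shorter than that of compound 4, or one carrying an amine or a carboxylic acid, would keep this level.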